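This account rests on a few compounds, and the source may have more. Where it says the series, first, only, none or still open, it means among the compounds named here.

In an ADME assay on HepG2 cells (Homo sapiens) for cytotoxicity, in the presence of a further agent that is not named here (a lower number here means a stronger inhibitor, a higher number a weaker inhibitor), compound 1 `CC(NC(=O)c1nc(Cc2ccccc2C(F)(F)F)n(C)c(=O)c1O)c1ccccc1` stands at > 100000 nM, which is a limit of the assay and not a number. Compound 2 `COc1nc(C(C)c2ccccc2C(F)(F)F)nc(C(=O)NCc2ccccc2)c1O` reads > 100000 nM, and this too is a limit. Compound 3 `Cn1c(Cc2ccccc2C(F)(F)F)nc(C(=O)NCc2ccccc2F)c(O)c1=O` keeps the core of compound 1 but carries 2-fluorobenzyl in place of 1-phenylethyl on an amide-type nitrogen. Among the compounds with values here, no measured step between these compounds is available, so the expected a number no higher from compound 1 to compound 3 (the limit leaves the size open) in this assay is none beyond the scatter, in either direction. For compound 3 the estimated value is 100000 nM, with an expected range from 60000 nM to 200000 nM.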

Compound 3, half-maximal inhibitory concentration: > 100000 nM
Compound 3: only a limit was reported; the forecaster's own chance of this, stated with the estimate: 90%; the middle value lies on the limit itself.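

No step from compound 1 to compound 3 can be read in this assay, because both values are limits of the assay and not numbers: the limit of > 100000 nM in this assay, at which 3 of the 3 values shown sit.

The compounds shown leave open at what concentration, if any, each would reach half-maximal inhibition in this assay.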